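Fluoro for methyl: from compound 2 to compound 4

The source may report more compounds than this note shows. Statements on the series, on what has been measured and on what is new or still open speak of the compounds shown alone.

For the measured compounds named here, compound 1 `O=S(=O)(Nc1ccc2oc(-c3ccc(NS(=O)(=O)c4cccc5nonc45)cc3)nc2c1)c1ccc(Cl)s1` is the one member of the set that returns a number in an assay on cells for inhibition of HSP60/HSP10 (Homo sapiens), with a stated time of 60 min; on this read-out higher numbers stand for weaker inhibition and lower numbers for stronger inhibition: compound 1 gives 13000 nM. Compound 2 `Cc1cccc(S(=O)(=O)Nc2ccc(-c3nc4ccccc4o3)cc2)c1` reaches only the limit of this assay, > 100000 nM. Compound 3 `COc1ccc(S(=O)(=O)Nc2ccc3oc(-c4ccccc4)nc3c2)cc1` also reaches only the limit, > 100000 nM. Compound 2 therefore stands at the limit of > 100000 nM in this assay, at which 2 of the 3 values shown sit, with no number of its own. Compound 4 `O=S(=O)(Nc1ccc(-c2nc3ccccc3o2)cc1)c1cccc(F)c1` differs from compound 2 in one place: fluoro in place of methyl on an aromatic carbon. Going by the values given here, no measured pair in the set shares this change, so the size of the step is open. Compound 4 is expected to remain at the limit. The expected step is a step that the limit leaves unreadable from compound 2 to compound 4, within the scatter. Compound 4 in this assay is estimated at 150000 nM, between 30000 nM and 600000 nM.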

Compound 4, half-maximal inhibitory concentration: 71000 nM
Compound 4: the middle estimate sits 2.1-fold (0.32 log units) above what was measured, and the stated range covers the measured number.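

Compound 2 gives > 100000 nM as a limit, not a number. In this assay the data show an at least 1.4-fold lower number from compound 2 to compound 4 (0.14 log units; that floor lies within the scatter) for the change from 3-methylphenyl to 3-fluorophenyl, so this position, with fluoro on the aromatic carbon, can carry a readable number. The true size of the step stays unread because one end of it is only a limit: the limit of > 100000 nM in this assay, at which 2 of the 4 values shown sit.

Still open, from the compounds shown here alone, is whether an amine, a hydroxyl or a carboxylic acid in this place would shift the number, and whether chloro would read like fluoro.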